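The source may hold more compounds than are shown below. What is called first, only, known or untested is meant among the compounds shown, and "the series" means these compounds.

Compound 3 `CC(C)CC(=O)O[C@H]1C[C@@H](C)C=C2C=C[C@H](C)[C@H](CC[C@@H]3C[C@@H](O)CC(=O)O3)C21` gives 5.4 nM in an assay for inhibition of 3-hydroxy-3-methylglutaryl-coenzyme A reductase (Rattus norvegicus) (a higher number here means a weaker inhibitor, a lower number a stronger inhibitor), the second highest of the three numbers: compound 1 `CCC(CC)(CC)C(=O)O[C@H]1C[C@@H](C)C=C2C=C[C@H](C)[C@H](CC[C@@H]3C[C@@H](O)CC(=O)O3)C21` gives 1.4 nM and compound 2 `CC(=O)O[C@H]1C[C@@H](C)C=C2C=C[C@H](C)[C@H](CC[C@@H]3C[C@@H](O)CC(=O)O3)C21` gives 269 nM. Compound 4 `C[C@H]1C=C2C=C[C@H](C)[C@H](CC[C@@H]3C[C@@H](O)CC(=O)O3)C2[C@@H](OC(=O)c2ccc(F)cc2)C1` differs from compound 3 by 4-fluorophenyl in place of isobutyl on a carbonyl carbon. Both measured steps at this carbonyl carbon bear on it: a 3.9-fold higher number from compound 1 to compound 3 (0.59 log units; beyond the scatter), and a 50-fold lower number from compound 2 to compound 3 (1.70 log units; beyond the scatter). Within these three compounds, the groups with more heavy atoms at this carbonyl carbon have given lower numbers, and the entering group is the larger by the counts shown, so a lower number is plausible. No aromatic ring has been measured in this place, however, so only a modest step is expected, a 1.1-fold lower number from compound 3 to compound 4 (0.03 log units; within the scatter). Compound 4 is estimated at 5 nM, with a range of 1.2 nM to 25 nM.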

Compound 4, half-maximal inhibitory concentration: 37 nM
Beside the measured number, compound 4's estimate is 7.4-fold (0.87 log units) below it; the measured number lies above the stated range.
By their numbers in this assay, from the lowest: compound 1; then compound 3; then compound 4; then compound 2.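

In this assay the heavy-atom count at this carbonyl carbon no longer orders the series: 4-fluorophenyl in place of isobutyl gives a 6.9-fold higher number from compound 3 to compound 4 (0.84 log units; beyond the scatter) despite being the larger group. Against methyl it gives a 7.3-fold lower number from compound 2 to compound 4 (0.86 log units; beyond the scatter) and against 1,1-diethylpropyl a 26-fold higher number from compound 1 to compound 4 (1.42 log units; beyond the scatter) so 4-fluorophenyl ranks behind both branched groups and ahead of methyl only. No supporting data are available to account for this reversal.

Still open, on these data alone, is whether the loss follows the aromatic ring or the fluorine. Plain phenyl and cyclohexyl on this carbonyl carbon would separate the two.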